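From Chloro to Dimethylamino in a Paw-Edema Series

The source may hold more compounds than are shown below. What is called first, only, known or untested is meant among the compounds shown, and "the series" means these compounds.

Compound 2 `O=C1N=C(C2C(=O)c3ccccc3C2=O)CC(c2ccc(Cl)cc2)N1` gives 15% in a functional assay on the whole organism for inhibition, with Rattus norvegicus as the target, read by paw edema, with stated times of 30 min and 1 h, at a dose of 10 mg/kg by the oral route; a lower number here means less inhibition, a higher number more inhibition at the dose given (going by the name of the read-out). Going by the values given here, of the two compounds measured so far it stands lowest, with compound 1 `O=C1N=C(C2C(=O)c3ccccc3C2=O)CC(c2ccccc2)N1` nearest at 20%; the step of a number 5 percentage points lower from compound 1 to compound 2 (within the scatter) lies within the scatter. Compound 3 `CN(C)c1ccc(C2CC(C3C(=O)c4ccccc4C3=O)=NC(=O)N2)cc1` awaits measurement in this assay. The change from compound 2 is dimethylamino in place of chloro on an aromatic carbon: the chloro leaves and a dimethylamino enters, on an aromatic carbon of a six-membered aromatic ring of carbon only, para to a large group. Among the compounds with values here, the only measured step, chloro entering for hydrogen on an aromatic carbon, was within the scatter, and no step exchanging chloro for dimethylamino has been measured. Compound 3 is therefore expected to show a step of a number 3 percentage points higher from compound 2 to compound 3 (within the scatter), nothing beyond the scatter. Compound 3 is estimated to give 18% in this assay, with a range from 5% to 35%.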

Compound 3, a percentage reported as inhibition, in the whole organism at one dose (the size of the read-out at that dose, not a potency): 15%
Beside the measured number, compound 3's estimate is 3 percentage points above it, and the stated range covers the measured number.
By their numbers in this assay, from the lowest: compounds 2, 3 and 1 (each within the scatter of the next).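

At the position para to a large group, in this assay, replacing chloro with dimethylamino, which has more heavy atoms and brings a hydrogen-bond acceptor, gives no change at the digits printed from compound 2 to compound 3 (within the scatter) and so leaves the read-out unmoved. Dimethylamino in place of hydrogen gives a number 5 percentage points lower from compound 1 to compound 3 (within the scatter) as well, so that, with a number 5 percentage points lower from compound 1 to compound 2 (within the scatter) as the chloro step, both groups now shown at this position remain within the scatter of compound 1 at this single dose. Nothing available bears on why these two different groups give such similar numbers.

Going by these compounds, whether a carboxylic acid or a longer alkyl chain at this position would move the read-out beyond the scatter remains open. So does whether a change to the shared core, rather than to this aromatic ring, would do so.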